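A Urea Ring Swap in the Azetidine Amide Series

A few compounds are considered here, and "the series" means these few. Any claim that something is new, unique, unknown or untested is made for them only; others in the source may bear on it.

Compound 1 `O=C([C@H]1CC2CCC1C2)N1CC(c2nc(-c3ccccc3)no2)C1` carries a bicyclic carboxamide on the shared core, and in an assay on HEK293 cells for positive allosteric modulation of metabotropic glutamate receptor 5 (Homo sapiens), read by FLIPR (a lower number here means that less compound is needed, a higher number that more compound is needed for the effect), compound 1 gives 120 nM. Compound 3 `O=C(C1CCC(C(F)(F)F)CC1)N1CC(c2nc(-c3cccc(Cl)c3)no2)C1` pairs a chlorinated aryl ring with a trifluoromethyl-bearing cyclohexyl carboxamide, and compound 3 gives 1000 nM in this assay. Compound 2 `CC1CCN(C(=O)N2CC(c3nc(-c4cccc(Cl)c4)no3)C2)C1` is a urea rather than a carboxamide, and for compound 2 the assay reports only a limit, > 10000 nM, so compound 2 stands at the limit of > 10000 nM in this assay, at which 1 of the 3 values shown sits, without a numerical value. Compound 4 `COC1CCCN(C(=O)N2CC(c3nc(-c4cccc(Cl)c4)no3)C2)C1` has not yet been measured. It differs from compound 2 in one place: 3-methoxypiperidin-1-yl in place of 3-methylpyrrolidin-1-yl on a carbonyl carbon. For the measured compounds named here, no step between two measured compounds is available for this change, so its size rests on the neighbouring compounds alone. Because compound 2 sits at the limit of > 10000 nM in this assay, at which 1 of the 3 values shown sits, compound 4 is expected to remain weak, with any step from the urea of compound 2 likely no larger than the scatter and possibly still ending at the limit. The expected step is an at least 1.2-fold lower number from compound 2 to compound 4 (0.09 log units; that floor lies within the scatter), estimated with little confidence. Compound 4 is therefore estimated to give 8000 nM, with a likely range from 2000 nM to 30000 nM.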

Compound 4, half-maximal effective concentration: > 10000 nM
Compound 4: only a limit was reported (the forecaster's own chance of this, stated with the estimate: 60%); at least 1.2-fold (0.09 log units) between middle value and limit.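

In this assay compound 4 gives > 10000 nM, which is a limit and not a number. Compound 2 also stands at a limit, so no step from compound 2 to compound 4 can be read: the limit of > 10000 nM in this assay, at which 2 of the 4 values shown sit.

The compounds shown leave open whether 3-methoxypiperidin-1-yl and 3-methylpyrrolidin-1-yl differ at all in this assay.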